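Cyanomethyl to propargyl on the shared core

A few compounds are considered here, and "the series" means these few. Any claim that something is new, unique, unknown or untested is made for them only; others in the source may bear on it.

In a functional assay on HepG2 cells (Homo sapiens) for cytotoxicity, read by sulforhodamine B assay, with a stated time of 48 h (on this read-out lower numbers stand for stronger inhibition and higher numbers for weaker inhibition), compound 1 (`N#Cc1c(-c2ccc(Cl)cc2)cc(-c2ccc(Cl)cc2)n(CC(O)CCl)c1=O`) gives 4.8 ug/mL and compound 2 (`N#Cc1c(-c2ccc(Cl)cc2)cc(-c2ccc(Cl)cc2)n([C@@H]2O[C@H](COC(=O)c3ccccc3)[C@@H](OC(=O)c3ccccc3)[C@H]2OC(=O)c2ccccc2)c1=O`) gives 8 ug/mL, two values within the usual scatter of each other. Among the measured compounds shown here, compound 3 (`N#CCn1c(-c2ccc(Cl)cc2)cc(-c2ccc(Cl)cc2)c(C#N)c1=O`) is reported as "not active" (no number reported), without a number, so it has no exact place on the scale and no step can be counted from it.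

Compound 4 (`C#CCn1c(-c2ccc(Cl)cc2)cc(-c2ccc(Cl)cc2)c(C#N)c1=O`) is the next to be read. The structural change is ethynyl in place of cyano on a saturated chain carbon bound to an aromatic nitrogen, or cyanomethyl to propargyl.

For the measured compounds named here, no measured step covers this change, so any expectation for this assay is loose. A shift from no number to a weak but measurable value is expected, in the region of compound 2 at 8 ug/mL or somewhat weaker, although a second report without a number remains possible. For compound 4 the estimated value is 10 ug/mL, with an expected range of 4 ug/mL to 40 ug/mL.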

Compound 4, half-maximal inhibitory concentration: 18.3 ug/mL
Estimate against measurement, compound 4: 1.8-fold (0.26 log units) below, within the range that was stated.
By their numbers in this assay, from the lowest: compounds 1 and 2 (each within the scatter of the next); then compound 4.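

In this assay compound 4 gives 18.3 ug/mL, so on this core a propargyl group yields a measurable value where the cyanomethyl group of compound 3 yields only a report without a number, and that step cannot be read as a size. Ethynyl in place of 2-chloro-1-hydroxyethyl on the saturated chain carbon bound to an aromatic nitrogen gives a 3.8-fold higher number from compound 1 to compound 4 (0.58 log units; beyond the scatter), which shows that the result at this position depends on the group placed there. No measurement at hand explains either difference.

A plain propyl chain in this place would show whether the ethynyl group itself separates compound 4 from compound 3. Going by these compounds, how an amine or a longer alkyne chain at this position would read in this assay remains open.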